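A few compounds are considered here, and "the series" means these few. Any claim that something is new, unique, unknown or untested is made for them only; others in the source may bear on it.

Compound 1 `COc1cc(-c2nnc3n2NC(c2ccco2)C(C(=O)c2ccc(Br)cc2)S3)cc(OC)c1OC` gives 42100 nM in a functional assay on A549 cells (Homo sapiens) for cytotoxicity, read by MTT assay, with a stated time of 48 h; a lower number here means a stronger inhibitor, a higher number a weaker inhibitor. Compound 2 `COc1cc(-c2nnc3n2NC(c2ccco2)C(C(=O)c2ccc(C)cc2)S3)cc(OC)c1OC` carries methyl in place of bromo on an aromatic carbon. In this assay compound 2 reaches only a limit of the assay, > 100000 nM. Among the compounds with values here, the single measured step, an at least 2.3-fold higher number from compound 1 to compound 2 (0.37 log units; beyond the scatter), ends at that limit (the limit of > 100000 nM in this assay, at which 1 of the 2 values shown sits). Compound 3 `COc1cc(-c2nnc3n2NC(c2ccco2)C(C(=O)c2ccco2)S3)cc(OC)c1OC` differs from compound 2 by furan-2-yl in place of 4-methylphenyl on a carbonyl carbon. Within the data shown here, no measured step touches a change on the carbonyl carbon, so in this assay no step beyond the scatter is expected, and the next value may again be a limit. Compound 3 is estimated at 90000 nM, between 30000 nM and 200000 nM, an expected at least 1.1-fold lower number from compound 2 to compound 3 (0.04 log units; that floor lies within the scatter).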

Compound 3, half-maximal inhibitory concentration: 68700 nM
Estimate against measurement, compound 3: 1.3-fold (0.12 log units) above; measured number inside the range.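

In this assay, furan-2-yl in place of 4-bromophenyl on the carbonyl carbon gives a 1.6-fold higher number from compound 1 to compound 3 (0.21 log units; within the scatter), so this change does not separate the two compounds. Furan-2-yl in place of 4-methylphenyl gives an at least 1.4-fold lower number from compound 2 to compound 3 (0.16 log units; that floor lies within the scatter), so this step shows no change beyond the scatter. Compound 2 stays a limit and not a number: the limit of > 100000 nM in this assay, at which 1 of the 3 values shown sits.

The compounds shown leave open whether an amine, a carboxylic acid or a longer chain in place of the ring on the carbonyl carbon would move the number beyond the scatter.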